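Swapping ethyl for trifluoromethoxy on a sulfonamide aryl ring

The source may report more compounds than this note shows. Statements on the series, on what has been measured and on what is new or still open speak of the compounds shown alone.

Measured compounds:
- compound 1, `CCc1ccc(S(=O)(=O)NCCC[C@H]2C(=O)N(c3ccc(C)cc3)[C@@H]2c2ccc([N+](=O)[O-])cc2)cc1`: >= 4.4 in a physicochemical assay for lipophilicity, read by HPLC, measured as octanol-water partition; on this read-out higher numbers stand for higher lipophilicity and lower numbers for lower lipophilicity
- compound 2, `CCc1ccc(S(=O)(=O)NCCC[C@H]2C(=O)N(c3ccc(C)cc3)[C@@H]2c2ccc(NS(C)(=O)=O)cc2)cc1`: 3.4
- compound 3, `CCc1ccc(S(=O)(=O)NCCC[C@H]2C(=O)N(c3ccc(C)cc3)[C@@H]2c2ccc(NS(=O)(=O)c3ccc(C)cc3)cc2)cc1`: 3.4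

The value of compound 1 in this assay is a limit, not a number (the limit of >= 4.4 in this assay, at which 1 of the 3 values shown sits). Compound 3 stands level with compound 2; the step of no change at the digits printed from compound 2 to compound 3 (within the scatter) lies within the scatter, whereas a number at least 1.00 log units lower from compound 1 to compound 3 (beyond the scatter) and a number at least 1.00 log units lower from compound 1 to compound 2 (beyond the scatter) were both clearly beyond it.

Compound 4, `Cc1ccc(N2C(=O)[C@H](CCCNS(=O)(=O)c3ccc(OC(F)(F)F)cc3)[C@H]2c2ccc(NS(=O)(=O)c3ccc(C)cc3)cc2)cc1`, differs from compound 3 only at the sulfonamide aryl ring: trifluoromethoxy in place of ethyl on an aromatic carbon. For the measured compounds named here, no measured step touches this place, so the expectation for compound 4 rests on compound 3 alone, and the step of a number 0.10 log units higher from compound 3 to compound 4 (within the scatter) is expected to stay within the scatter. Compound 4 is therefore estimated at 3.5, between 3.1 and 3.9.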

Compound 4, partition coefficient: 3.4
Compound 4: middle estimate off by 0.10 log units, on the high side; low and high end bracket the measured number.
By their numbers in this assay, from the lowest: compounds 2, 3 and 4 (each within the scatter of the next). At a limit, above all of these: compound 1.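

In this assay, for the compounds shown here, the earlier steps all changed a different place, so this is the only reading at the sulfonamide aryl ring: trifluoromethoxy in place of ethyl gives no change at the digits printed from compound 3 to compound 4 (within the scatter). Here, a group of 5 heavy atoms replaces one of 2 without moving the read-out beyond the scatter, at least with the rest of compound 3 held fixed. Nothing measured here explains this result.

From the compounds shown here alone, it remains open whether the same swap behaves alike with the nitro group of compound 1 or the methanesulfonamido group of compound 2 elsewhere in the molecule. An amine or a carboxylic acid at this place on the ring also remains untested among the compounds shown.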